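Compound 3 to compound 4: ethyl out, fluoro in

A few compounds are considered here, and "the series" means these few. Any claim that something is new, unique, unknown or untested is made for them only; others in the source may bear on it.

In a functional assay on A-375 cells (Homo sapiens) for antiproliferative activity, read by MTT assay, with a stated time of 24 h (a higher number here means a weaker inhibitor, a lower number a stronger inhibitor), compound 3 `CCc1ccc2nc(C(=O)Nc3c(F)cc(-c4cccc(F)c4)cc3F)c(C)c(C(=O)O)c2c1` gives 57800 nM. Compound 1 `Cc1c(C(=O)Nc2c(F)cc(-c3cccc(F)c3)cc2F)nc2ccc(F)cc2c1O` gives 65300 nM, within the scatter of compound 3. Compound 2 `Cc1ccc2nc(C(=O)Nc3c(F)cc(-c4cccc(F)c4)cc3F)c(C)c(C(=O)O)c2c1` gives 26000 nM, the lowest number of the three and beyond the scatter from both others.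

Compound 4 `Cc1c(C(=O)Nc2c(F)cc(-c3cccc(F)c3)cc2F)nc2ccc(F)cc2c1C(=O)O` differs from compound 3 by fluoro in place of ethyl on an aromatic carbon. For the measured compounds named here, no measured step makes this exchange. The nearest evidence is a 2.2-fold higher number from compound 2 to compound 3 (0.35 log units; beyond the scatter), a modest step with methyl in place of hydrogen on a saturated chain carbon bound to an aromatic carbon. Losing the ethyl may therefore partly reverse that step in this assay, although fluoro is not methyl and the transfer is loose. Going by the values given here, the expected change is a 1.7-fold lower number from compound 3 to compound 4 (0.22 log units; within the scatter), toward a lower number but no larger than the step between compound 2 and compound 3. For compound 4 the estimated value is 35000 nM, with an expected range of 14000 nM to 85000 nM.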

Compound 4, half-maximal inhibitory concentration: 81900 nM
Beside the measured number, compound 4's estimate is 2.3-fold (0.37 log units) below it; the measured number falls inside the stated range.
By their numbers in this assay, from the lowest: compound 2; then compounds 3, 1 and 4 (each within the scatter of the next).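

Fluoro in place of ethyl at this position gives a 1.4-fold higher number from compound 3 to compound 4 (0.15 log units; within the scatter) in this assay and so does not separate the two groups. Fluoro in place of methyl gives a 3.2-fold higher number from compound 2 to compound 4 (0.50 log units; beyond the scatter) as its step, so among the three groups seen at this position, methyl alone stands apart from the other two. With fluoro held at this position, carboxy in place of hydroxy on an aromatic carbon gives a 1.3-fold higher number from compound 1 to compound 4 (0.10 log units; within the scatter) and does not separate these two groups either.

No measurement on hand accounts for these numbers. Going by these compounds, whether a methoxy group or an amine at this position would stand with methyl, or with ethyl and fluoro, remains open, as does whether the methyl result holds with hydroxy in place of carboxy.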